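Sulfonyl aryl swap and liver microsome clearance

The source may report more compounds than this note shows. Statements on the series, on what has been measured and on what is new or still open speak of the compounds shown alone.

Measured compounds:
Compound 1 `O=S(=O)(c1cc(F)cc(F)c1)c1cnc2c(F)cccc2c1-c1ccccc1F` gives 0.09 mL/min in an ADME assay on microsomes from liver (Homo sapiens) for metabolic stability, tested at 2.5 uM; on this read-out higher numbers stand for fast clearance and lower numbers for slow clearance.
Compound 2 `O=S(=O)(c1ccc(F)c(Cl)c1)c1cnc2cc(F)ccc2c1-c1ccc(Cl)cc1` gives 0.39 mL/min in this assay.
Compound 3 `O=S(=O)(c1ccc(F)c(Cl)c1)c1cnc2c(F)cccc2c1-c1ccccc1F` gives 1.39 mL/min in this assay.

Compound 3 and compound 1 share a core and differ only by 3,5-difluorophenyl in place of 3-chloro-4-fluorophenyl on a sulfonyl sulfur. That change brought a 15-fold lower number from compound 3 to compound 1 (1.19 log units; beyond the scatter). Compound 4 `O=S(=O)(c1cc(F)cc(F)c1)c1cnc2cc(F)ccc2c1-c1ccc(Cl)cc1`, not yet measured in this assay, arises from compound 2 by 3,5-difluorophenyl in place of 3-chloro-4-fluorophenyl on a sulfonyl sulfur; this is the same kind of change, though the difference between the two cores is not broken down here. Compound 2 sits between compound 3 and compound 1 in this assay. The step from compound 2 to compound 4 is expected to be a 6.5-fold lower number from compound 2 to compound 4 (0.81 log units; beyond the scatter), resting on the earlier step of a 15-fold lower number from compound 3 to compound 1 (1.19 log units; beyond the scatter), though on a different core. Compound 4 is therefore expected to give 0.06 mL/min in this assay, with a range from 0.02 mL/min to 0.18 mL/min.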

Compound 4, intrinsic clearance in a liver preparation (reported as CLH), per the amount of preparation that the assay uses: 0.03 mL/min
Estimate against measurement, compound 4: 2.0-fold (0.30 log units) above, and the stated range covers the measured number.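

In this assay, 3,5-difluorophenyl in place of 3-chloro-4-fluorophenyl on a sulfonyl sulfur gave a 13-fold lower number from compound 2 to compound 4 (1.11 log units; beyond the scatter). Set beside the earlier step on the other core, the change carried over with no difference in size that stands out from the scatter: the same change on two cores in this assay, a 15-fold lower number (1.19 log units; beyond the scatter) from compound 3 to compound 1 and a 13-fold lower number (1.11 log units; beyond the scatter) from compound 2 to compound 4, 1.2-fold (0.07 log units) apart, within the scatter of two such steps. This shows that the step held on these two cores, but it does not show that it would hold on any further core, and it does not say why the number falls.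

The compounds shown leave open what an amine or a carboxylic acid on the aryl ring at the sulfonyl sulfur would do to this read-out. They also leave open whether the same swap would give a step of this size with such a group present.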